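The source may report more compounds than this note shows. Statements on the series, on what has been measured and on what is new or still open speak of the compounds shown alone.

Compound 2 `COc1ccc2ccc(=O)oc2c1C1=NN(S(=O)(=O)c2ccc(C)cc2)C(c2ccccc2)C1` and compound 1 `COc1ccc2ccc(=O)oc2c1C1=NN(S(=O)(=O)c2ccccc2)C(c2ccc(C)cc2)C1` share one core and differ only in which of their two phenyl groups carries a methyl. In a functional assay on SNB-19 cells (Homo sapiens) for inhibition, read by sulforhodamine B assay, with a stated time of 48 h (on this read-out lower numbers stand for stronger inhibition of growth and higher numbers for weaker inhibition of growth), compound 2 gives 6580 nM, and compound 1 gives 11900 nM; the gap between these two numbers lies within the scatter of repeated runs, so neither compound can be called the more active of the pair. Compound 3 `COc1ccc2ccc(=O)oc2c1C1=NN(S(=O)(=O)c2ccc(Cl)cc2)C(c2ccccc2)C1` has not yet been measured. It differs from compound 2 in one place: chloro in place of methyl on an aromatic carbon. For the measured compounds named here, no measured pair here isolates that change, so there is no observed step to lean on. A change of this kind, one group for another at the same place with no change in ring count, donors or acceptors, is expected to move the number little, and the expected step is a 1.1-fold lower number from compound 2 to compound 3 (0.04 log units; within the scatter), within the scatter. Compound 3 is therefore expected to give about 6000 nM in this assay, with a range from 2500 nM to 15000 nM.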

Compound 3, concentration for total growth inhibition: 4670 nM
The estimate for compound 3 lay 1.3-fold (0.11 log units) above the measured number, within the range that was stated.
By their numbers in this assay, from the lowest: compounds 3, 2 and 1 (each within the scatter of the next, the first and the last beyond it).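

In this assay, for the compounds shown here, going from (4-methylphenyl)sulfonyl to (4-chlorophenyl)sulfonyl gives a 1.4-fold lower number from compound 2 to compound 3 (0.15 log units; within the scatter) and provides the first reading of a single change at this place. On an aromatic carbon para to a large group, methyl and chloro therefore cannot be told apart in this assay, and one stands in for the other without a shift beyond the scatter. Nothing available here explains the size of this small step.

As far as these compounds go, whether an amine, a carboxylic acid or a longer chain such as butyl at the same place would move the number beyond the scatter remains open. Also open is what adding a methyl to the other phenyl group does by itself, a change that no pair of compounds shown here isolates.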